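This account rests on a few compounds, and the source may have more. Where it says the series, first, only, none or still open, it means among the compounds named here.

Going by the values given here, in a functional assay on HeLa cells (Homo sapiens) for antiproliferative activity, read by MTT assay, with a stated time of 72 h (a lower number here means a stronger inhibitor, a higher number a weaker inhibitor), compound 3 `O=C1O[C@H]([C@@H](O)Cn2cc(CNS(=O)(=O)c3ccc(Cl)cc3)nn2)C(OCc2ccccc2)=C1OCc1ccccc1` gives 13600 nM, the lowest of the three numbers measured so far. Compound 2 `Cc1ccc(-c2cn(C[C@H](O)[C@H]3OC(=O)C(OCc4ccccc4)=C3OCc3ccccc3)nn2)cc1` gives 25500 nM, and compound 1 `O=C1O[C@H]([C@@H](O)Cn2cc(CCO)nn2)C(OCc2ccccc2)=C1OCc1ccccc1` gives 68800 nM. The step of a 1.9-fold lower number from compound 2 to compound 3 (0.27 log units; within the scatter) lies within the scatter, while the step of a 5.1-fold lower number from compound 1 to compound 3 (0.70 log units; beyond the scatter) lies beyond it. Compound 4 `CCCCc1cn(C[C@H](O)[C@H]2OC(=O)C(OCc3ccccc3)=C2OCc2ccccc2)nn1` differs from compound 3 in one place: propyl in place of ((4-chlorophenyl)sulfonyl)amino on a saturated chain carbon bound to an aromatic carbon. Among the compounds with values here, the only measured step that bears on this is a 5.1-fold lower number from compound 1 to compound 3 (0.70 log units; beyond the scatter), which runs the opposite way, putting the ((4-chlorophenyl)sulfonyl)amino group in rather than taking it out, so a rise in the number of similar size is expected. Compound 4 is therefore expected to give 45000 nM, between 15000 nM and 130000 nM, an expected step of a 3.3-fold higher number from compound 3 to compound 4 (0.52 log units; beyond the scatter).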

Compound 4, half-maximal inhibitory concentration: 18100 nM
The estimate for compound 4 lay 2.5-fold (0.40 log units) above the measured number; low and high end bracket the measured number.
By their numbers in this assay, from the lowest: compounds 3, 4 and 2 (each within the scatter of the next); then compound 1.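

In this assay the change from the ((4-chlorophenyl)sulfonyl)amino group to propyl, which drops a whole aromatic ring, leaves the number within the scatter (a 1.3-fold higher number from compound 3 to compound 4 (0.12 log units; within the scatter)), so the larger group is not needed at this level of activity. Butyl and 4-methylphenyl also stay within the scatter of each other (a 1.4-fold lower number from compound 2 to compound 4 (0.15 log units; within the scatter)), and only compound 1, with its terminal hydroxy, stands apart (a 3.8-fold lower number from compound 1 to compound 4 (0.58 log units; beyond the scatter)). Nothing measured here explains why this hydroxy group sets compound 1 apart.

Going by these compounds, it remains open whether an amine, a carboxylic acid or a chain longer than butyl at this place would move the number beyond the scatter.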